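From pyridazin-3-yl to pyrimidin-4-yl on a sulfonamide nitrogen

The source may hold more compounds than are shown below. What is called first, only, known or untested is meant among the compounds shown, and "the series" means these compounds.

Results so far in a physicochemical assay for lipophilicity (on this read-out higher numbers stand for higher lipophilicity and lower numbers for lower lipophilicity), are:
Compound 1 `Cc1nc(-c2cc(C(F)(F)F)ccc2[C@H]2CCOc3cc(S(=O)(=O)Nc4ccncn4)ccc32)co1` gives "not determined" (no result reported)
Compound 2 `Cn1nccc1-c1cc(C(F)(F)F)ccc1[C@H]1CCOc2cc(S(=O)(=O)Nc3cccnn3)ccc21` gives 2.2

For the measured compounds named here, compound 2 at 2.2 holds the only number so far, so it has no measured neighbour to be ranked against. Attention now turns to compound 3 `Cn1nccc1-c1cc(C(F)(F)F)ccc1[C@H]1CCOc2cc(S(=O)(=O)Nc3ccncn3)ccc21`, which has not yet been measured. The change pyrimidin-4-yl in place of pyridazin-3-yl on a sulfonamide nitrogen puts pyrimidin-4-yl in place of pyridazin-3-yl on a sulfonamide nitrogen, with the same atoms joined differently. Compound 1 also carries pyrimidin-4-yl there, but it offers no number as a guide. Going by the values given here, with no measured step to draw on, the expected change is a number 0.10 log units higher from compound 2 to compound 3 (within the scatter) in this assay and no move beyond the scatter in either direction. That expectation rests on compound 2 at 2.2 alone. Compound 3 is estimated at 2.3 with a range of 1.8 to 2.8 expected.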

Compound 3, distribution coefficient: 1.8
The estimate for compound 3 lay 0.50 log units above the measured number; the measured number falls inside the stated range.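

Pyrimidin-4-yl in place of pyridazin-3-yl on a sulfonamide nitrogen gives a number 0.40 log units lower from compound 2 to compound 3 (beyond the scatter) in this assay, the first measured step at this position. The two groups have the same atoms joined differently and the same printed counts of heavy atoms, donors and acceptors, yet the read-out moves beyond the scatter, so those counts alone do not settle the value here. Nothing among the data shown accounts for the step.

On these data alone, this remains a single pair, and compound 1 gives no number, so whether the step carries over to a compound with another group elsewhere on the core stays open. Also open, as far as these compounds go, is how a phenyl or thiazol-2-yl ring on the same sulfonamide nitrogen would read.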